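Swapping the pyrazole for a cyano-methylpyrrole in a triazine series

A few compounds are considered here, and "the series" means these few. Any claim that something is new, unique, unknown or untested is made for them only; others in the source may bear on it.

Two compounds share a core and differ only in the ring attached to one nitrogen. Compound 1 `N#Cc1cc(Nc2nc(N)nc(-c3cccc(-n4ccc5cc(C6CC6)cc(F)c5c4=O)c3CO)n2)cn1C1CC1` gives 4000 nM in a physicochemical assay for solubility, read by LC-MS, measured as kinetic solubility, with a stated time of 1 h; on this read-out higher numbers stand for higher solubility and lower numbers for lower solubility. Compound 2 `Nc1nc(Nc2cn[nH]c2)nc(-c2cccc(-n3ccc4cc(C5CC5)cc(F)c4c3=O)c2CO)n1` gives 12000 nM in this assay, the highest of the two numbers, and the step of a 3.0-fold higher number from compound 1 to compound 2 (0.48 log units; beyond the scatter) lies beyond the scatter.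

Compound 3 `Cn1cc(Nc2nc(N)nc(-c3cccc(-n4ccc5cc(C6CC6)cc(F)c5c4=O)c3CO)n2)cc1C#N` has not yet been measured. Its change from compound 2 is 5-cyano-1-methyl-1H-pyrrol-3-yl in place of 1H-pyrazol-4-yl on a nitrogen on an aromatic ring. For the measured compounds named here, this largely reverses the earlier step, since the ring that enters resembles the one that left compound 1, with a methyl where a cyclopropyl stood. On that basis a drop of about the same size as a 3.0-fold higher number from compound 1 to compound 2 (0.48 log units; beyond the scatter), read backwards, is expected, and compound 3 is estimated to move by a 2.4-fold lower number from compound 2 to compound 3 (0.38 log units; beyond the scatter). In this assay compound 3 is therefore expected to give 5000 nM, within a range of 2000 nM to 12000 nM.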

Compound 3, solubility: 670 nM
Beside the measured number, compound 3's estimate is 7.5-fold (0.87 log units) above it, and the stated range ends above it.
By their numbers in this assay, from the lowest: compound 3; then compound 1; then compound 2.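

The two rings carrying a nitrile do not behave as one group in this assay: with methyl in place of cyclopropyl on an aromatic nitrogen, the result is a 6.0-fold lower number from compound 1 to compound 3 (0.78 log units; beyond the scatter). So the small group on that nitrogen counts, not only the identity of the ring attached to the amino link. The ring change at this position also reaches an 18-fold lower number from compound 2 to compound 3 (1.25 log units; beyond the scatter), a large step that compound 1 and compound 2 alone gave no sign of.

Nothing measured here accounts for the effect of either change. Still open, on these data alone, is how an ethyl group or a longer chain on that aromatic nitrogen would read, and whether a methyl group on the nitrogen of the 1H-pyrazol-4-yl ring would bring a similar drop.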